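The source may report more compounds than this note shows. Statements on the series, on what has been measured and on what is new or still open speak of the compounds shown alone.

Compound 1: `Cc1cccc(-c2cc(Cl)cc(Cl)c2/C=C/[C@@H]2C[C@@H](O)CC(=O)O2)c1`, 16 nM in an assay for inhibition of 3-hydroxy-3-methylglutaryl-coenzyme A reductase (Rattus norvegicus); a higher number here means a weaker inhibitor, a lower number a stronger inhibitor. Compound 2: `Cc1cc(C)cc(-c2cc(Cl)cc(Cl)c2/C=C/[C@@H]2C[C@@H](O)CC(=O)O2)c1`, 13 nM in this assay.

Compound 2 gives the lowest of the two numbers in this assay, but a 1.2-fold lower number from compound 1 to compound 2 (0.09 log units; within the scatter), so the two compounds sit within the scatter of each other and no order can be read from them. Compound 3 is `Cc1ccc(-c2cc(Cl)cc(Cl)c2/C=C/[C@@H]2C[C@@H](O)CC(=O)O2)cc1`; it differs from compound 2 by 4-methylphenyl in place of 3,5-dimethylphenyl on an aromatic carbon. Within the data shown here, the only measured step that bears on it is the one from compound 1 to compound 2, which moved one methyl on the same ring and stayed within the scatter; no measured pair shows a methyl moved to the position it takes in compound 3. Compound 3 is therefore expected to stay close to compound 2, with a 1.2-fold higher number from compound 2 to compound 3 (0.09 log units; within the scatter) and no step beyond the scatter. Compound 3 is estimated at 16 nM, in the range 6 nM to 45 nM.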

Compound 3, half-maximal inhibitory concentration: 190 nM
Beside the measured number, compound 3's estimate is 12-fold (1.07 log units) below it; the whole stated range lies below it.
By their numbers in this assay, from the lowest: compounds 2 and 1 (each within the scatter of the next); then compound 3.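

On this aromatic carbon, ortho to a large group, the placing of the methyl on the phenyl ring decides the result in this assay: 4-methylphenyl in place of 3,5-dimethylphenyl gives a 15-fold higher number from compound 2 to compound 3 (1.16 log units; beyond the scatter), and 4-methylphenyl in place of 3-methylphenyl gives a 12-fold higher number from compound 1 to compound 3 (1.07 log units; beyond the scatter). The earlier step showed only that a second methyl on the 3-methylphenyl ring left the number within the scatter, whereas compound 1 and compound 3 differ only in where a single methyl stands, so the place of the methyl matters here and not merely its presence. Nothing available accounts for this difference.

On these data alone, how an unsubstituted phenyl or a 4-methoxyphenyl group would read on this carbon remains open. It therefore cannot be said whether the higher number of compound 3 comes from the methyl it carries or from the one it lacks.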